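From compound 2 to compound 3: estimating a half-life

The source may report more compounds than this note shows. Statements on the series, on what has been measured and on what is new or still open speak of the compounds shown alone.

Compound 1 `C=CCN(CCCC(=O)O)C(=O)/C(C)=C/c1ccc(C(=O)Oc2ccc(C(=N)N)cc2)cc1`: 0.917 h
Compound 2 `C=CCN(CCC(=O)OCC)C(=O)/C(C)=C/c1ccc(C(=O)Oc2ccc(C(=N)N)cc2)cc1`: 1 h

In an in vitro ADME assay on the whole organism (small intestine) for pharmacokinetics, with Rattus norvegicus as the target (on this read-out lower numbers stand for a shorter-lived compound and higher numbers for a longer-lived compound), compound 2 gives 1 h, level with compound 1 within the usual scatter. Compound 3 `CCN(CC(=O)O)C(=O)/C(C)=C/c1ccc(C(=O)Oc2ccc(C(=N)N)cc2)cc1` differs from compound 2 as follows: (carboxymethyl)(ethyl)amino in place of allyl(2-(ethoxycarbonyl)ethyl)amino on a carbonyl carbon. In words, this is (carboxymethyl)(ethyl)amino in place of allyl(2-(ethoxycarbonyl)ethyl)amino on a carbonyl carbon. For the measured compounds named here, only one measured step bears on this change, a 1.1-fold higher number from compound 1 to compound 2 (0.04 log units; within the scatter), and it stays within the scatter. It exchanges ethoxycarbonyl and carboxymethyl, so no step beyond the scatter, in either direction, is expected in this assay. The expected step is a 1.1-fold lower number from compound 2 to compound 3 (0.05 log units; within the scatter). The estimated value for compound 3 is 0.9 h, with an expected range from 0.4 h to 2 h.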

Compound 3, half-life: > 1 h
Compound 3 gave a limit, no number; the forecaster's own chance of this, stated with the estimate: 3%; middle value at least 1.1-fold (0.04 log units) away from the limit.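

In this assay, compound 3 gives a limit, not a number: the limit of > 1 h in this assay, at which 1 of the 3 values shown sits. Replacing allyl(2-(ethoxycarbonyl)ethyl)amino with the smaller (carboxymethyl)(ethyl)amino on this carbonyl carbon gives a number no lower from compound 2 to compound 3 (the limit leaves the size open) (the size of that step cannot be read). The other comparison is an at least 1.0-fold higher number from compound 1 to compound 3 (0.03 log units; that floor lies within the scatter), so this position shows no sign of a shorter half-life with the smaller group.

From the compounds shown here alone, how far compound 3 really lies from the others stays open, as does which part of the exchanged group matters. How a dimethylamino group would behave at this carbonyl carbon is also unknown.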